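Trifluoromethoxy in Place of Trifluoromethyl: an Expected Value

This account rests on a few compounds, and the source may have more. Where it says the series, first, only, none or still open, it means among the compounds named here.

Compound 1, `O=S(=O)(NC1=NCCN1C(=S)SN1CCn2c1nsc2=S)c1ccccc1`: in a functional assay on KYSE-510 cells (Homo sapiens) for antiproliferative activity, read by crystal violet staining, with a stated time of 96 h (a higher number here means a weaker inhibitor of growth, a lower number a stronger inhibitor of growth), compound 1 gives >= 20000 nM, which is a limit of the assay and not a number.
Compound 2, `O=S(=O)(NC1=NCCN1C(=S)SN1CCn2c1nsc2=S)c1ccc(C(F)(F)F)cc1`: in this assay compound 2 gives >= 20000 nM, again a limit and not a number.

From the compounds shown here alone, compound 2 therefore stands only at a limit in this assay; where it truly lies is unknown. Going by the values given here, the single measured step, a step that the two limits leave unreadable from compound 1 to compound 2, cannot be read because the limit of >= 20000 nM in this assay, at which 2 of the 2 values shown sit, hides where either compound lies. Compound 3, `O=S(=O)(NC1=NCCN1C(=S)SN1CCn2c1nsc2=S)c1ccc(OC(F)(F)F)cc1`, differs from compound 2 by trifluoromethoxy in place of trifluoromethyl on an aromatic carbon. Among the compounds with values here, no measured step bears on this change, so the expectation rests on the limit alone. Compound 3 is estimated to give 30000 nM in this assay, within a range of 8000 nM to 150000 nM, and most probably again only as a limit. The expected step is a step that the limit leaves unreadable from compound 2 to compound 3, with no direction that can be claimed beyond the scatter.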

Compound 3, concentration for 50% growth inhibition: >= 20000 nM
Compound 3: a limit, no number; the forecaster's own chance of this, stated with the estimate: 85%; the middle value does not contradict the limit.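

No new step can be read from compound 2 to compound 3 or from compound 1 to compound 3, because each of these compounds stands only at a limit, not a number: the limit of >= 20000 nM in this assay, at which 3 of the 3 values shown sit.

The compounds shown leave open where each one truly lies, and whether trifluoromethyl or trifluoromethoxy changes growth inhibition at all.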